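A few compounds are considered here, and "the series" means these few. Any claim that something is new, unique, unknown or untested is made for them only; others in the source may bear on it.

Three compounds built on a shared core were tested in an ADME assay on PC-3 cells (Homo sapiens) for cytotoxicity, read by WST assay, tested at 100 uM; a higher number here means more inhibition at the concentration tested (going by the name of the read-out), a lower number less inhibition. Compound 1 `CC(C)(C)OC(=O)c1cccc(NC(=O)C2CCCN(C(=O)c3cc(C(F)(F)F)cc(C(F)(F)F)c3)C2)c1` gives 0%. Compound 2 `Cc1nc(-c2cccc(C(=O)N3CCCC(C(=O)Nc4ccc(Cl)cc4)C3)c2)no1` gives 0%, and compound 3 `O=C(Nc1ccc(Cl)cc1)C1CCCN(C(=O)c2cccc([N+](=O)[O-])c2)C1` gives 0%. Compound 1 therefore stands level with compound 2 and compound 3; the three values lie within the usual scatter of one another, so no order can be read among them.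

Among the measured compounds shown here, the one comparison between measured compounds that involves a single change is no change at the digits printed from compound 2 to compound 3 (within the scatter). It shows that exchanging one group on an aromatic carbon left the read-out where it was.

Compound 4 `O=C(Nc1cccc(Oc2ccccc2)c1)C1CCCN(C(=O)c2cc(C(F)(F)F)cc(C(F)(F)F)c2)C1` differs from compound 1 in one place: phenoxy in place of tert-butoxycarbonyl on an aromatic carbon. For the measured compounds named here, no measured step matches this exact change; the only guide is that compound 2 and compound 3 show no change between them, and that compound 1, compound 2 and compound 3 all sit at the same read-out despite carrying different groups on their aromatic carbons. The step expected from compound 1 to compound 4 is therefore no change at the digits printed from compound 1 to compound 4 (within the scatter), none beyond the scatter. Compound 4 is expected to give 0% in this assay, with a range from -10% to 15%.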

Compound 4, a percentage reported as inhibition, at one concentration (the size of the read-out at that concentration, not a potency): 1%
Beside the measured number, compound 4's estimate is 1 percentage points below it, within the range that was stated.
By their numbers in this assay, from the lowest: compounds 1, 2, 3 and 4 (each within the scatter of the next).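

In this assay, the aromatic carbon meta to a large group takes phenoxy in place of tert-butoxycarbonyl with a number 1 percentage points higher from compound 1 to compound 4 (within the scatter), and this is the first single change shown at this position. The earlier step changed a different group on a different set of compounds, so it said nothing directly about this place on the core of compound 1. The two groups here have the same count of heavy atoms, yet one has no ring and the other brings a six-membered aromatic ring of carbon only, and that difference in shape of the group leaves the read-out within the scatter; no measurement shown gives any reason for this result.

The compounds shown leave open whether any other group at this position would lift the read-out clear of the scatter, for instance an amine, a carboxylic acid or a longer alkyl chain. They also leave open whether a change at this position would behave the same way on compounds that carry a different group on the other aromatic ring of the shared core.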